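A Furan for Phenyl on a Shared Nucleoside Core

The source may hold more compounds than are shown below. What is called first, only, known or untested is meant among the compounds shown, and "the series" means these compounds.

Compound 1 `COc1ncnc2c1c(-c1ccccc1)cn2[C@@H]1O[C@H](CO)[C@@H](O)[C@H]1O` was examined in a functional assay on CCRF-CEM cells (Homo sapiens), read by MTT assay, with a stated time of 72 h; on this read-out lower numbers stand for stronger inhibition and higher numbers for weaker inhibition. In this assay compound 1 gives > 20000 nM, which is a limit of the assay and not a number. Compound 2 `CNc1ncnc2c1c(-c1ccccc1)cn2[C@@H]1O[C@H](CO)[C@@H](O)[C@H]1O` carries methylamino in place of methoxy on an aromatic carbon. In this assay compound 2 gives > 20000 nM, again a limit rather than a number. For the measured compounds named here, the only measured step is a step that the two limits leave unreadable from compound 1 to compound 2, so compound 1 stands at the limit and no readable step is available; the whole of the measured evidence is the limit of > 20000 nM in this assay, at which 2 of the 2 values shown sit.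

Compound 3 `COc1ncnc2c1c(-c1ccco1)cn2[C@@H]1O[C@H](CO)[C@@H](O)[C@H]1O` differs from compound 1 by furan-2-yl in place of phenyl on an aromatic carbon. Going by the values given here, no measured step bears on this change, and the single step that exists is unreadable, so neither a direction nor a size can be drawn from the measurements. With both measured values sitting at a limit, compound 3 is expected to remain near that limit, with an estimated 30000 nM and a range from 8000 nM to 100000 nM. The expected step is a step that the limit leaves unreadable from compound 1 to compound 3, understood as no change that the assay could read.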

Compound 3, half-maximal inhibitory concentration: 20 nM
Compound 3: middle estimate off by 1500-fold (3.18 log units), on the high side; measured number below the stated range.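

In this assay, the group on the aromatic carbon two ring bonds from the ring nitrogen proves able to move the read-out away from the limit: furan-2-yl in place of phenyl, with the methoxy group kept, gives an at least 1000-fold lower number from compound 1 to compound 3 (3.00 log units; beyond the scatter). For the compounds shown here, the earlier pair offered no such view, since both compounds carry phenyl and the one step between them cannot be read, so this is the first readable change on the shared core and the first sign that the phenyl compounds' lack of a readable value need not hold for the whole series. The size of this step is tied to a starting point that is only a limit, and what is shown gives the change no cause: the limit of > 20000 nM in this assay, at which 2 of the 3 values shown sit.

From the compounds shown here alone, it remains open whether furan-2-yl would have the same effect with methylamino in place of methoxy, or whether the result depends on the pairing with methoxy. Going by these compounds, it also remains open whether the gain is particular to furan-2-yl or would extend to other five-membered rings on the same carbon, such as thiophen-2-yl, furan-3-yl or pyrrol-2-yl.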